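The compounds below may be only part of what the source reports. "The series", "measured", "known", "first", "only" and "open" are said of these compounds alone.

Working notes on the shared core. Compound 1 `Cn1cc(SCc2nnc(SCc3ccccc3)n2-c2c(Cl)cccc2Cl)c2ccccc21` is the phenyl member; in a toxicity assay on HEK-293T cells (Homo sapiens) for cytotoxicity, read by CCK-8 assay, with a stated time of 48 h (on this read-out higher numbers stand for lower toxicity in this test and lower numbers for higher toxicity in this test), compound 1 reports only a limit of the assay, > 100000 nM. Compound 3 `Cn1cc(SCc2nnc(SCc3c(Cl)cccc3Cl)n2-c2c(Cl)cccc2Cl)c2ccccc21`, the 2,6-dichlorophenyl member, likewise gives only a limit in this assay, > 100000 nM. Going by the values given here, compound 2 `Cn1cc(SCc2nnc(SCc3cc(C(F)(F)F)ccc3Cl)n2-c2c(Cl)cccc2Cl)c2ccccc21`, with 2-chloro-5-(trifluoromethyl)phenyl on a saturated chain carbon bound to a sulfur, is the one compound with a read number, giving 53800 nM in this assay, and so stands alone as the sole value below (the limit of > 100000 nM in this assay, at which 2 of the 3 values shown sit). The measured steps are an at least 1.8-fold lower number from compound 1 to compound 2 (0.26 log units; that floor lies within the scatter), an at least 1.8-fold higher number from compound 2 to compound 3 (0.26 log units; that floor lies within the scatter) and a step that the two limits leave unreadable from compound 1 to compound 3.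

Compound 4 `Cn1cc(SCc2nnc(SCc3c(F)cccc3Cl)n2-c2c(Cl)cccc2Cl)c2ccccc21` is not yet measured. Against compound 2 the change is 2-chloro-6-fluorophenyl in place of 2-chloro-5-(trifluoromethyl)phenyl on a saturated chain carbon bound to a sulfur. The step that bears on it is an at least 1.8-fold higher number from compound 2 to compound 3 (0.26 log units; that floor lies within the scatter), where a ring carrying two halogens returned to the limit; compound 4 brings a related ring, with fluorine in place of one chlorine. A small step toward higher numbers, possibly back to the limit, is therefore expected: a 1.8-fold higher number from compound 2 to compound 4 (0.25 log units; within the scatter). For compound 4 the estimate in this assay is 95000 nM, with a range of 45000 nM to 200000 nM.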

Compound 4, half-maximal cytotoxic concentration: > 100000 nM
Compound 4 ended at the assay's limit; the forecaster's own chance of this, stated with the estimate: 55%; middle value at least 1.0-fold (0.02 log units) away from the limit.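

In this assay, a second mixed ring at the place on a saturated chain carbon bound to a sulfur, 2-chloro-6-fluorophenyl, ends at a limit of the assay rather than at a read number, giving an at least 1.8-fold higher number from compound 2 to compound 4 (0.26 log units; that floor lies within the scatter). Fluoro in place of chloro on an aromatic carbon, the change from compound 3, therefore brings no read number, and the steps from compound 1 and from compound 3 to compound 4 cannot be read, as both ends are limits. Compound 2 remains the only member with a read number, and the rest of the series shares one ceiling: the limit of > 100000 nM in this assay, at which 3 of the 4 values shown sit.

On these data alone, whether a phenyl carrying trifluoromethyl alone would also give a read number stays open. So does the reading in this assay for a ring bearing an amine or a carboxylic acid at this place.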